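This account rests on a few compounds, and the source may have more. Where it says the series, first, only, none or still open, it means among the compounds named here.

Working notes on the series. Of the compounds shown here, three of the shared core have been measured in a functional assay on DU-145 cells (Homo sapiens) for inhibition, read by trypan blue exclusion, with a stated time of 96 h; on this read-out higher numbers stand for weaker inhibition of growth and lower numbers for stronger inhibition of growth. Compound 1 `O=C(O)c1ccc(C(=O)/C(=C\c2ccc(Cl)c([N+](=O)[O-])c2)SCc2ccccc2F)cc1` gives 1000 nM. Going by the values given here, compound 2 `O=C(O)c1ccc(C(=O)/C(=C\c2ccc(Cl)c([N+](=O)[O-])c2)SCc2ccc(Br)cc2)cc1` gives 500 nM, and the step of a 2.0-fold lower number from compound 1 to compound 2 (0.30 log units; within the scatter) is the only single-place step among the measured compounds. Compound 3 `O=C(O)c1ccc(C(=O)/C(=C\c2ccc(F)c([N+](=O)[O-])c2)SCc2ccc(Cl)cc2Cl)cc1` gives 1000 nM; compound 3 stands level with compound 1 at the digits shown, the two together the highest of the three numbers, and its gap to compound 2 is within the scatter, so no ordering among the three is claimed.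

Compound 4 `O=C(O)c1ccc(C(=O)/C(=C\c2ccc(Cl)c([N+](=O)[O-])c2)SCc2ccc(Cl)cc2Cl)cc1` differs from compound 3 in one place: chloro in place of fluoro on an aromatic carbon. The change sits on the aromatic carbon ortho to the nitro group, para to a large group, so that 4-fluoro-3-nitrophenyl becomes 4-chloro-3-nitrophenyl. Among the compounds with values here, no measured step touches this position; the step from compound 1 to compound 2 concerns the other ring and says nothing about a halogen exchange here. With nothing in the data bearing on the change, the expectation is a step of no change at the digits printed from compound 3 to compound 4 (within the scatter), that is none beyond the scatter. Compound 4 is therefore estimated at 1000 nM, with a range from 400 nM to 2500 nM.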

Compound 4, concentration for 50% growth inhibition: 1000 nM
For compound 4 middle estimate and measured number coincide at the digits printed; the measured number falls inside the stated range.
By their numbers in this assay, from the lowest: compounds 2, 1, 3 and 4 (each within the scatter of the next).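

In this assay, going by these compounds alone, the exchange of fluoro for chloro on the aromatic carbon ortho to a nitro group gives no change at the digits printed from compound 3 to compound 4 (within the scatter) and is the first reading at this position, so with 2,4-dichlorophenyl held fixed on the saturated chain carbon bound to a sulfur, 4-fluoro-3-nitrophenyl and 4-chloro-3-nitrophenyl cannot be told apart here. Compound 4 also adds two readings on the other ring with 4-chloro-3-nitrophenyl held fixed: 2,4-dichlorophenyl in place of 4-bromophenyl gives a 2.0-fold higher number from compound 2 to compound 4 (0.30 log units; within the scatter) and 2,2,4-dichlorophenyl in place of 2-fluorophenyl gives no change at the digits printed from compound 1 to compound 4 (within the scatter) and neither step separates from the scatter, so that ring has so far shown no difference that can be read. No measurement at hand offers an explanation for these results.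

As far as these compounds go, whether anything other than a halogen on this aromatic carbon, such as an amine or a methoxy group, would move the number beyond the scatter remains open. Also open, from the compounds shown here alone, is whether a nitrile in place of the nitro group, or a longer chain between the sulfur and the outer ring, would separate from the four numbers now in hand.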